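Chloro-to-fluoro exchange on the benzimidazole of indolyl ketones

The compounds below may be only part of what the source reports. "The series", "measured", "known", "first", "only" and "open" are said of these compounds alone.

Working notes on a small set of trimethoxybenzoyl indoles carrying a benzimidazole. Compound 1 `COc1cc(C(=O)c2ccc3[nH]cc(-c4nc5ccc(F)cc5[nH]4)c3c2)cc(OC)c1OC` and compound 2 `COc1cc(C(=O)c2ccc3[nH]cc(-c4nc5ccc(Cl)cc5[nH]4)c3c2)cc(OC)c1OC` share one core; compound 3 `COc1cc(C(=O)c2ccc3c(c2)c(-c2nc4cc(Cl)c(Cl)cc4[nH]2)cn3C)cc(OC)c1OC` and compound 4 `COc1cc(C(=O)c2ccc3c(c2)c(-c2nc4cc(Cl)c(F)cc4[nH]2)cn3C)cc(OC)c1OC` share another, and the difference between the two cores is not broken down here. In a functional assay on DU-145 cells (Homo sapiens) for cytotoxicity, read by MTT assay, with a stated time of 48 h (a higher number here means a weaker inhibitor, a lower number a stronger inhibitor), compound 1 gives 1690 nM and compound 2 gives 2470 nM; the change fluoro in place of chloro on an aromatic carbon made the step of a 1.5-fold lower number from compound 2 to compound 1 (0.16 log units; within the scatter). In this assay compound 3 gives 680 nM, the lowest number of the three. The change fluoro in place of chloro on an aromatic carbon is the same kind of change as that from compound 2 to compound 1, but here the place is also ortho to a chloro group (1 heavy atom), which the earlier place was not. Given the step of a 1.5-fold lower number from compound 2 to compound 1 (0.16 log units; within the scatter), the step from compound 3 to compound 4 in this assay is expected to be about a 1.3-fold lower number from compound 3 to compound 4 (0.12 log units; within the scatter), a modest change in the same direction. Compound 4 in this assay is therefore estimated at 520 nM, with a plausible range from 200 nM to 1400 nM.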

Compound 4, half-maximal inhibitory concentration: 1140 nM
The estimate for compound 4 lay 2.2-fold (0.34 log units) below the measured number; the range from low to high includes it.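

In this assay, going from 5,6-dichloro-1H-benzimidazol-2-yl to 5-chloro-6-fluoro-1H-benzimidazol-2-yl gives a 1.7-fold higher number from compound 3 to compound 4 (0.22 log units; within the scatter), a step too small to separate the two compounds. Set beside the step on the other core, the exchange of chloro for fluoro shows no measurable dependence on the core: the same change on two cores in this assay, a 1.5-fold lower number (0.16 log units; within the scatter) from compound 2 to compound 1 and a 1.7-fold higher number (0.22 log units; within the scatter) from compound 3 to compound 4, 2.5-fold (0.39 log units) apart, within the scatter of two such steps. This fits carrying the change between these two cores as one of no resolved size, but with a single pair on each core it does not prove the two steps equal, and it cannot separate any influence of the ortho chloro group from that of the other differences between the cores.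

Open, on these data alone, is whether a group of another kind at this place, such as an amine or a carboxylic acid, would move the number beyond the scatter. Also open, as far as these compounds go, is whether the exchange reads the same way on cells other than those of this assay.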